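Shortening a Ring to a Chain on the Amide Carbonyl

The source may hold more compounds than are shown below. What is called first, only, known or untested is meant among the compounds shown, and "the series" means these compounds.

This piece follows a single small change within one family of compounds. Compound 1, with the structure `O=C(NCC1CCc2ccccc2N1Cc1ccccc1)C1CCC1`, has in a functional assay on CHO cells with melatonin receptor type 1A (Homo sapiens) as the target, read by GTPgammaS binding, with a stated time of 1 h (on this read-out lower numbers stand for smaller maximal responses and higher numbers for larger maximal responses), only the entry "not determined" (no result reported), so there is no number on which it can be placed. A related compound, compound 2, with the structure `CCNC(=O)NCC1CCc2c(OC)cccc2N1C`, does have a result: in this assay compound 2 gives 92%, which shows that a member of this family can drive the response close to the full level of the reference.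

Compound 3, with the structure `CCC(=O)NCC1CCc2ccccc2N1Cc1ccccc1`, is compound 1 with one alteration, (ethyl in place of cyclobutyl on a carbonyl carbon). Within the data shown here, no measured pair shows what this particular exchange does in this assay, and with compound 1 itself unmeasured the direction of any step cannot be read from the data; the only anchor is the high response of compound 2.

On that basis the largest response of compound 3 in this assay is expected to be about 85%, with a likely range from 45% to 110%.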

Compound 3, largest response reached (Emax), in percent of the reference or control that the assay uses: 42%
Compound 3: the middle estimate sits 43 percentage points above what was measured; the measured number lies below the stated range.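

Among these compounds, with compound 1 at "not determined" (no result reported) and compound 3 at 42% no step between the two can be read. The compounds shown leave open how the exchange of cyclobutyl for ethyl changes the largest response. Nothing shown bears on this result.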